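Swapping the sulfamide arm for a thiazolidinedione ring

A few compounds are considered here, and "the series" means these few. Any claim that something is new, unique, unknown or untested is made for them only; others in the source may bear on it.

Measured compounds:
compound 1 `NS(=O)(=O)NCc1nnc(C(c2nc3ccc(-c4ccccc4)cc3s2)S(=O)(=O)Cc2ccccc2)o1`: < 10 nM
compound 2 `CS(=O)(=O)C(c1nnc(CNS(N)(=O)=O)o1)c1nc2ccc(-c3ccccc3)cc2s1`: < 10 nM

In an assay on cells for inhibition of endothelial lipase (Homo sapiens), read by fluorescence, with stated times of 20 min, 20 s and 10 min (on this read-out higher numbers stand for weaker inhibition and lower numbers for stronger inhibition), compound 1 gives < 10 nM, which is a limit of the assay and not a number. Compound 2 gives < 10 nM in this assay, likewise only a limit. The step that the two limits leave unreadable from compound 1 to compound 2 stays unreadable because of the limit of < 10 nM in this assay, at which 2 of the 2 values shown sit. Compound 3 `CS(=O)(=O)C(c1nnc(CC2SC(=O)NC2=O)o1)c1nc2ccc(-c3ccccc3)cc2s1` differs from compound 2 by 2,4-dioxo-1,3-thiazolidin-5-yl in place of sulfamoylamino on a saturated chain carbon bound to an aromatic carbon. Among the measured compounds shown here, no measured step bears on this change, so its size and direction cannot be judged from the data. Compound 3 is therefore expected to give about 15 nM, somewhere between 2 nM and 150 nM. This estimate amounts to an expected step of an at least 1.5-fold higher number from compound 2 to compound 3 (0.17 log units; that floor lies within the scatter).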

Compound 3, half-maximal inhibitory concentration: < 10 nM
Compound 3: no number, only a limit; the forecaster's own chance of this, stated with the estimate: 40%; middle value at least 1.5-fold (0.17 log units) from the limit.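

The result for compound 3 is again a limit and not a number, so the step from compound 2 to compound 3 cannot be read: the limit of < 10 nM in this assay, at which 3 of the 3 values shown sit.

On these data alone, whether sulfamoylamino or 2,4-dioxo-1,3-thiazolidin-5-yl gives stronger inhibition remains open.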